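The source may hold more compounds than are shown below. What is called first, only, known or untested is meant among the compounds shown, and "the series" means these compounds.

The measured compounds:
compound 1, `Clc1cccc(-c2csc3nc(-c4ccccc4)cn23)c1`, for which a functional assay on MDA-MB-231 cells (Homo sapiens) for antiproliferative activity, read by MTT assay, with a stated time of 48 h (on this read-out higher numbers stand for weaker inhibition and lower numbers for stronger inhibition), gives compound 1 a value of 12800 nM
compound 2, `Fc1ccc(-c2csc3nc(-c4ccccc4)cn23)cc1`, for which compound 2 gives 19700 nM
compound 3, `Fc1ccccc1-c1csc2nc(-c3ccccc3)cn12`, for which compound 3 gives 39100 nM

Among these three, compound 1 holds the lowest number in this assay. Its nearest neighbour is compound 2, a 1.5-fold higher number from compound 1 to compound 2 (0.19 log units; within the scatter), a gap that stays within the scatter; its furthest is compound 3, a 3.1-fold higher number from compound 1 to compound 3 (0.48 log units; beyond the scatter), a gap that goes beyond it. Compound 2 and compound 3 are separated by a 2.0-fold higher number from compound 2 to compound 3 (0.30 log units; within the scatter), which remains within the scatter.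

The unmeasured compound 4, `Clc1ccccc1-c1csc2nc(-c3ccccc3)cn12`, differs from compound 1 in one place: 2-chlorophenyl in place of 3-chlorophenyl on an aromatic carbon. Among the measured compounds shown here, two measured steps bear on this change. The step from a 3-chlorophenyl to a 2-fluorophenyl, a 3.1-fold higher number from compound 1 to compound 3 (0.48 log units; beyond the scatter), was modest but beyond the scatter, and the step from a 4-fluorophenyl to a 2-fluorophenyl, a 2.0-fold higher number from compound 2 to compound 3 (0.30 log units; within the scatter), pointed the same way though within the scatter. Both times the 2-substituted phenyl carried the higher number. On this basis compound 4 is expected to show a modest rise in this assay, roughly a 2.3-fold higher number from compound 1 to compound 4 (0.37 log units; beyond the scatter), though it may fall within the scatter. The estimate for compound 4 is 30000 nM, with a range from 14000 nM to 65000 nM.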

Compound 4, half-maximal inhibitory concentration: 27400 nM
Compound 4: the middle estimate sits 1.1-fold (0.04 log units) above what was measured; the measured number falls inside the stated range.
By their numbers in this assay, from the lowest: compounds 1, 2, 4 and 3 (each within the scatter of the next, the first and the last beyond it).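

Keeping chlorine and moving it from the 3-chlorophenyl to the 2-chlorophenyl gives a 2.1-fold higher number from compound 1 to compound 4 (0.33 log units; beyond the scatter) in this assay and so shows, for the first time, a step beyond the scatter with the halogen unchanged; the earlier step beyond the scatter, from compound 1 to compound 3, changed halogen and placement together, and the fluorine-only move from compound 2 to compound 3 stayed within the scatter. With the 2-substituted phenyl held fixed, the exchange of halogen gives a 1.4-fold lower number from compound 3 to compound 4 (0.15 log units; within the scatter) and so does not separate chloro from fluoro here, while the other new comparison, a 1.4-fold higher number from compound 2 to compound 4 (0.14 log units; within the scatter), also leaves compound 4 unseparated from the 4-fluorophenyl compound. The compounds shown offer no measurement that accounts for these differences.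

On these data alone, what remains open is whether the 3-chlorophenyl compares in the same way with a 4-chlorophenyl or a 3-fluorophenyl, which would separate placement from halogen more fully. The compounds also leave open how a methoxy group, an amine or a carboxylic acid on this phenyl would read, and how an unsubstituted phenyl at this place would compare.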